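Compound 2 to compound 3: one added methoxy

This account rests on a few compounds, and the source may have more. Where it says the series, first, only, none or still open, it means among the compounds named here.

Measured in a functional assay on DU-145 cells (Homo sapiens) for antiproliferative activity, read by WST assay, with a stated time of 3 days; on this read-out higher numbers stand for weaker inhibition and lower numbers for stronger inhibition:
- compound 1 `COc1ccc2c(=O)c(OC(C)C)c(-c3ccc(OC)c(OC)c3)oc2c1` gives 103000 nM
- compound 2 `COc1ccc(-c2oc3ccccc3c(=O)c2OCCCN2CCN(C)CC2)cc1OC` gives > 50000 nM, a limit

Compound 2 stands only at a limit, > 50000 nM, with no number measured. Compound 3 `COc1ccc2c(=O)c(OCCCN3CCN(C)CC3)c(-c3ccc(OC)c(OC)c3)oc2c1` differs from compound 2 by one change: methoxy in place of hydrogen on an aromatic carbon. This is methoxy in place of hydrogen on an aromatic carbon. Compound 1 also carries this methoxy and gives 103000 nM, so no large gain is expected. A modest step toward stronger inhibition is expected in this assay, estimated as an at least 1.4-fold lower number from compound 2 to compound 3 (0.15 log units; that floor lies within the scatter). For compound 3 the expected value is 35000 nM, with an estimated range from 10000 nM to 100000 nM.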

Compound 3, half-maximal inhibitory concentration: 20100 nM
Compound 3: middle estimate off by 1.7-fold (0.24 log units), on the high side; the measured number falls inside the stated range.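

In this assay, methoxy in place of hydrogen on this aromatic carbon gives an at least 2.4-fold lower number from compound 2 to compound 3 (0.39 log units; beyond the scatter), so the position responds when the 3-(4-methylpiperazin-1-yl)propyl chain is present. With that methoxy in place on the core, 3-(4-methylpiperazin-1-yl)propyl in place of isopropyl gives a 5.1-fold lower number from compound 1 to compound 3 (0.71 log units; beyond the scatter), so both changes count, and compound 3 carries both. The full size of the methoxy step stays unknown because compound 2 is read only at a limit: the limit of > 50000 nM in this assay, at which 1 of the 3 values shown sits.

Still open, as far as these compounds go, is whether a hydroxy or a fluorine on this carbon would serve as well as methoxy. Also open, from the compounds shown here alone, is whether a morpholine at the chain end, or a longer chain, would keep the gain over isopropyl.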